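Adding a Methoxy to a Compound at the Limit

The compounds below may be only part of what the source reports. "The series", "measured", "known", "first", "only" and "open" are said of these compounds alone.

In a functional assay on PC-3 cells (Homo sapiens) for cytotoxicity, read by MTT assay, with a stated time of 48 h (a lower number here means a stronger inhibitor, a higher number a weaker inhibitor), compound 1 (`COc1ccc(/C=C/C(=O)/C=C/c2cc3ccccc3nc2Cl)cc1`) reaches only a limit, > 10000 nM. Compound 2 (`COc1cc(OC)c(OC)cc1/C=C/C(=O)/C=C/c1cc2ccccc2nc1Cl`), which carries more methoxy groups, gives a true number, 3120 nM. Compound 3 (`COc1ccc(/C=C/C(=O)/C=C/c2cc3ccccc3nc2Oc2ccccc2)cc1`) also reaches only a limit, > 10000 nM. It therefore stands at the limit of > 10000 nM in this assay, at which 2 of the 3 values shown sit. Phenoxy in place of chloro gives a step that the two limits leave unreadable from compound 1 to compound 3, so the one measured step offers no usable size.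

Compound 4 (`COc1ccc(/C=C/C(=O)/C=C/c2cc3ccccc3nc2Oc2ccccc2)cc1OC`) differs from compound 3 by methoxy in place of hydrogen on an aromatic carbon, which turns 4-methoxyphenyl into 3,4-dimethoxyphenyl. Within the data shown here, no measured step isolates this change. Among the measured compounds shown here, the only hint is compound 2 at 3120 nM, a single compound that keeps chloro and so offers weak support. A modest gain in strength is expected, though compound 4 may well stay at the limit. Compound 4 is estimated at 7000 nM, with an expected range of 2000 nM to 20000 nM. The expected change is an at least 1.4-fold lower number from compound 3 to compound 4 (0.15 log units; that floor lies within the scatter).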

Compound 4, half-maximal inhibitory concentration: > 10000 nM
Compound 4: a limit, no number (the forecaster's own chance of this, stated with the estimate: 45%); at least 1.4-fold (0.15 log units) between middle value and limit.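

Compound 3 and compound 4 both reach only a limit, so no step can be read between them: the limit of > 10000 nM in this assay, at which 3 of the 4 values shown sit.

The compounds shown leave open whether 3,4-dimethoxyphenyl in place of 4-methoxyphenyl changes the strength of a phenoxy compound at all in this assay.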